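The source may report more compounds than this note shows. Statements on the series, on what has been measured and on what is new or still open speak of the compounds shown alone.

Measured compounds:
compound 1 `CCN(CC)CN1C(=O)/C(=N\c2nc3ccc(C)cc3s2)c2c(Br)cccc21`, 16100 nM
compound 2 `CCN(CC)CN1C(=O)C(=O)c2c(Br)cccc21`, 113000 nM
compound 3 `CCN(CC)CN1C(=O)C(=O)c2c(Cl)cccc21`, 35000 nM

All three were run in an ADME assay on MCF-10A cells (Homo sapiens) for cytotoxicity, read by sulforhodamine B assay, with a stated time of 48 h; a lower number here means a stronger inhibitor of growth, a higher number a weaker inhibitor of growth. Compound 1 gives the lowest of the three numbers; compound 3 stands nearest, compound 2 furthest from it. Among the measured compounds shown here, compound 2 and compound 3 share a core; the single change between them is chloro in place of bromo on an aromatic carbon, and it gives a 3.2-fold lower number from compound 2 to compound 3 (0.51 log units; beyond the scatter). The difference between the core of compound 1 and the core of compound 2 is not broken down here.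

Compound 4 `CCN(CC)CN1C(=O)/C(=N\c2nc3ccc(C)cc3s2)c2c(Cl)cccc21` is not yet measured in this assay. From compound 1 it differs by chloro in place of bromo on an aromatic carbon, the same change as from compound 2 to compound 3, at a place described in the same words. Carrying that step onto the other core, a step of about a 2.7-fold lower number from compound 1 to compound 4 (0.43 log units; beyond the scatter) is expected for compound 4, resting on the single measured pair, with the caveat that the two cores differ in a way not counted here. The estimate for compound 4 in this assay is 6000 nM, expected within 2500 nM to 15000 nM.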

Compound 4, concentration for 50% growth inhibition: 43900 nM
Beside the measured number, compound 4's estimate is 7.3-fold (0.86 log units) below it; measured number outside the range, above it.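

In this assay, chloro in place of bromo on an aromatic carbon gives a 2.7-fold higher number from compound 1 to compound 4 (0.44 log units; beyond the scatter), so the direction seen on the core of compound 2 does not carry over to the core of compound 1. Set side by side, the two steps run in opposite directions: the same change on two cores in this assay, a 3.2-fold lower number (0.51 log units; beyond the scatter) from compound 2 to compound 3 and a 2.7-fold higher number (0.44 log units; beyond the scatter) from compound 1 to compound 4, 8.8-fold (0.94 log units) apart, beyond the scatter of two such steps

Among the compounds shown here, with only one pair on each core, this shows that the step measured on one core does not predict the step on the other here; it does not show which part of the difference between the cores goes with the reversal, or how the same change would run on a further core.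

The compounds shown leave open whether fluoro, methyl or plain hydrogen on the same aromatic carbon would follow the trend of the pair on the core of compound 1 or the pair on the core of compound 2. Also open, on these data alone, is whether the reversal persists when the diethylamino group is replaced by another amine, such as morpholine.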